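Methyl to Ethyl on the Imidazole of Compound 3

This account rests on a few compounds, and the source may have more. Where it says the series, first, only, none or still open, it means among the compounds named here.

compound 1, `Cn1ccnc1-c1cccc(Cl)c1CCc1cc(Br)ccc1O`, in an assay on isolated protein for binding affinity to Melanocortin receptor 4 (Homo sapiens) (a higher number here means a weaker inhibitor, a lower number a stronger inhibitor), compound 1 gives 9300 nM
compound 2, `COc1ccc(Br)cc1CCc1c(F)cccc1-c1ncc2n1CCC2`, in this assay compound 2 gives 320 nM
compound 3, `COc1ccc(Br)cc1CCc1ccccc1-c1ncc(C)n1C`, in this assay compound 3 gives 180 nM

Among the three measured compounds, compound 3 stands at the lowest number in this assay. Its nearest neighbour is compound 2, whose value lies within the scatter of that of compound 3, so no order between the two can be claimed. Compound 1 lies far beyond the scatter and is clearly the weaker of the set.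

The next compound, compound 4, `CCc1cnc(-c2ccccc2CCc2cc(Br)ccc2OC)n1C`, differs from compound 3 by a single change: methyl in place of hydrogen on a saturated chain carbon bound to an aromatic carbon. For the measured compounds named here, no step between measured compounds shows what such an addition does, so the expectation rests on the small size of the change alone. One extra carbon on an already substituted chain is the kind of alteration that usually moves a value little.

Compound 4 is therefore expected to give 180 nM in this assay, with a range from 70 nM to 450 nM. The step of no change at the digits printed from compound 3 to compound 4 (within the scatter) that this estimate means is expected to stay within the scatter, in no particular direction.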

Compound 4, inhibition constant: 320 nM
Compound 4: the middle estimate sits 1.8-fold (0.25 log units) below what was measured; the range from low to high includes it.
By their numbers in this assay, from the lowest: compounds 3, 2 and 4 (each within the scatter of the next); then compound 1.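

For the compounds shown here, the step from methyl to ethyl gives the first direct reading at this position: in this assay the change gives a 1.8-fold higher number from compound 3 to compound 4 (0.25 log units; within the scatter) and so stays within the scatter. Going by these compounds alone, on a saturated chain carbon bound to an aromatic carbon, one added methyl therefore produces no step that can be told apart from repeat measurement, though this rests on a single pair of compounds. Nothing shown bears on why the value behaves this way.

Going by these compounds, whether a longer chain such as propyl, a branched isopropyl, an amine or a carboxylic acid at this carbon would stay near compound 3 at 180 nM remains open. Also open, on these data alone, is whether the same addition would read alike on the cores of compound 1 and compound 2.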